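This account rests on a few compounds, and the source may have more. Where it says the series, first, only, none or still open, it means among the compounds named here.

Measured in a functional assay, read by spectrophotometry, with a stated time of 20 min; a lower number here means a stronger inhibitor, a higher number a weaker inhibitor:
- Compound 1 `Cc1c(-c2ccccc2Cl)oc2ccccc2c1=O`: 192 ug/mL
- Compound 2 `COc1ccc(-c2oc3ccccc3c(=O)c2C)cc1`: 100 ug/mL

Compound 2, at 100 ug/mL, holds the lower of the two numbers, yet it lies within the usual scatter of compound 1 at 192 ug/mL. Compound 3 `Cc1c(-c2ccc(F)cc2)oc2ccccc2c1=O` has fluoro in place of methoxy on an aromatic carbon, para to a large group (fluoro in place of methoxy on an aromatic carbon). Among the measured compounds shown here, no measured pair shows the size of this change, so no step beyond the scatter is expected in this assay, in either direction. The expected step is a 1.3-fold higher number from compound 2 to compound 3 (0.11 log units; within the scatter). The estimate for compound 3 is 130 ug/mL, with an expected range from 55 ug/mL to 300 ug/mL.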

Compound 3, half-maximal inhibitory concentration: 114 ug/mL
Compound 3: the middle estimate sits 1.1-fold (0.06 log units) above what was measured; the measured number falls inside the stated range.
By their numbers in this assay, from the lowest: compounds 2, 3 and 1 (each within the scatter of the next).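

Among the compounds shown here, this is the first matched pair, and it gives the position a measured step: in this assay, fluoro in place of methoxy on this aromatic carbon, para to a large group, gives a 1.1-fold higher number from compound 2 to compound 3 (0.06 log units; within the scatter). Here, a change from two heavy atoms to one, with the loss of a hydrogen-bond acceptor, leaves the two numbers indistinguishable. No evidence on hand explains this result.

As far as these compounds go, whether an amine or a carboxylic acid on this carbon would move the number beyond the scatter remains open. So does whether a longer chain such as butoxy would be accommodated here.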